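This account rests on a few compounds, and the source may have more. Where it says the series, first, only, none or still open, it means among the compounds named here.

In a functional assay on HGC-27 cells (Homo sapiens) for cytotoxicity, read by MTT assay, with a stated time of 48 h (on this read-out lower numbers stand for stronger inhibition and higher numbers for weaker inhibition), three compounds have been measured so far. Compound 1 `COc1cc(OC)c(/C=C/C(=O)/C=C/c2cc3ccccc3nc2Oc2ccccc2)c(OC)c1`, which carries a 2,4,6-trimethoxyphenyl, gives > 10000 nM, and this is a limit rather than a number. Compound 2 `COc1ccc(OC)c(/C=C/C(=O)/C=C/c2cc3ccccc3nc2Oc2ccc(Br)cc2)c1` gives > 10000 nM, which is also a limit. Compound 3 `COc1ccc(/C=C/C(=O)/C=C/c2cc3ccccc3nc2Oc2ccc(Br)cc2)cc1OC` gives > 10000 nM, again a limit. Compound 3 therefore has no exact position on the scale, and neither do the other two: the whole set stands at the limit of > 10000 nM in this assay, at which 3 of the 3 values shown sit.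

The next compound is compound 4 `COc1cc(OC)c(/C=C/C(=O)/C=C/c2cc3ccccc3nc2Oc2ccc(Br)cc2)c(OC)c1`. Its change from compound 3 is 2,4,6-trimethoxyphenyl in place of 3,4-dimethoxyphenyl on a double-bonded chain carbon bound to a double-bonded chain carbon. In words, 2,4,6-trimethoxyphenyl takes the place of 3,4-dimethoxyphenyl on a double-bonded chain carbon bound to a double-bonded chain carbon.

Going by the values given here, only one measured step bears on this swap, since it also exchanges the same kind of group at the same place: a step that the two limits leave unreadable from compound 2 to compound 3. That step has no readable size, so it offers no size or direction to carry forward. No step beyond the usual scatter is therefore expected, and another limit is the likeliest report.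

The expected change is a step that the limit leaves unreadable from compound 3 to compound 4. If a number is reported for compound 4, the estimate is 15000 nM, with an expected range from 5000 nM to 40000 nM.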

Compound 4, half-maximal inhibitory concentration: > 10000 nM
Compound 4: no number, only a limit (the forecaster's own chance of this, stated with the estimate: 75%); the middle value does not contradict the limit.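

Going by these compounds alone, compound 4 gives only a limit, as do compound 1, compound 2 and compound 3, so no new step between them can be read. All of the values shown stand at one place: the limit of > 10000 nM in this assay, at which 4 of the 4 values shown sit. The compounds shown leave open how far each one's actual value lies from that limit, and which of them, if any, is stronger.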